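One Change at the Carbonyl Carbon of Compound 3

The source may hold more compounds than are shown below. What is called first, only, known or untested is meant among the compounds shown, and "the series" means these compounds.

Compound 1 `O=C(Nc1cccc(-n2cc(-c3ccncc3)c(-c3cc(O)cc(Cl)c3)n2)c1)Nc1ccc(Cl)c(Cl)c1`: 71%
Compound 2 `COc1cc(Cl)cc(-c2nn(-c3cccc(NC(=O)Nc4cc(C(F)(F)F)cc(C(F)(F)F)c4)c3)cc2-c2ccncc2)c1`: 38%
Compound 3 `COc1cc(Cl)cc(-c2nn(-c3cccc(NC(=O)Nc4ccc(Cl)c(Cl)c4)c3)cc2-c2ccncc2)c1`: 84%

In a functional assay on 786-0 cells (Homo sapiens) for inhibition, read by sulforhodamine B assay, with a stated time of 48 h, tested at 1 uM (on this read-out lower numbers stand for a stronger effect and higher numbers for a weaker effect at the one concentration tested), compound 3 gives 84%, the highest number of the three; the nearest lies a number 13 percentage points higher from compound 1 to compound 3 (beyond the scatter) away, and compound 2 sits much lower. Compound 4 `COc1cc(Cl)cc(-c2nn(-c3cccc(NC(=O)c4cccc(C(F)(F)F)c4)c3)cc2-c2ccncc2)c1` differs from compound 3 in one place: 3-(trifluoromethyl)phenyl in place of (3,4-dichlorophenyl)amino on a carbonyl carbon. Among the measured compounds shown here, the only step measured, a number 13 percentage points higher from compound 1 to compound 3 (beyond the scatter), concerns methyl in place of hydrogen on an oxygen on an aromatic ring, so it carries no lesson for this carbonyl carbon. The two values of compound 2 and compound 3 merely show that changes at this end of the core can move the read-out widely. With nothing firmer to lean on, compound 4 is estimated at 70%, between 40% and 100%. That estimate means an expected a number 14 percentage points lower from compound 3 to compound 4 (beyond the scatter).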

Compound 4, a percentage reported as activity, at one concentration (the size of the read-out at that concentration, not a potency): 56%
Compound 4: the middle estimate sits 14 percentage points above what was measured; the measured number falls inside the stated range.
By their numbers in this assay, from the lowest: compound 2; then compound 4; then compound 1; then compound 3.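

In this assay, among the compounds shown here, putting 3-(trifluoromethyl)phenyl in place of (3,4-dichlorophenyl)amino on the carbonyl carbon gives a number 28 percentage points lower from compound 3 to compound 4 (beyond the scatter), the first measured step at this position, and it points to a stronger effect at the one concentration tested. The group that leaves carries a hydrogen-bond donor and the group that enters carries none, but the step alone cannot separate that loss from the change of ring substituents. Nothing available here accounts for the shift.

The compounds shown leave open whether the amino nitrogen or the ring substituents carry the step. They also leave open how a cyclohexyl group or a longer alkyl chain on this carbonyl carbon would read.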